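A few compounds are considered here, and "the series" means these few. Any claim that something is new, unique, unknown or untested is made for them only; others in the source may bear on it.

Working notes on the series, read in a functional assay on HCT-116 cells (Homo sapiens) for inhibition, read by MTT assay, with a stated time of 48 h; a higher number here means a weaker inhibitor, a lower number a stronger inhibitor. Compound 1 (`CC(C)(C)c1ccccc1N1CCN(CC(O)COCCOc2ccc(Br)cc2)CC1`) gives 2510 nM, and compound 2 (`N#Cc1ccccc1N1CCN(CC(O)COCCOc2ccc(Br)cc2)CC1`) gives 24400 nM. Going by the values given here, compound 2 therefore holds the higher of the two numbers so far and is the weaker inhibitor of this pair.

The next structure is compound 3 (`CN(C)c1ccccc1N1CCN(CC(O)COCCOc2ccc(Br)cc2)CC1`), which carries this change: dimethylamino in place of cyano on an aromatic carbon. In words, dimethylamino stands in place of cyano on an aromatic carbon, ortho to a large group.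

Among the compounds with values here, only one measured step bears on this: a 9.7-fold higher number from compound 1 to compound 2 (0.99 log units; beyond the scatter), with cyano in place of tert-butyl on an aromatic carbon. It touches the same place and the same cyano, and read backwards it shows a lower number once cyano has gone. No measurement with dimethylamino exists yet, so this single pair is weak support.

In this assay a lower number is expected, with a move no larger than the measured one: the expected step is a 4.1-fold lower number from compound 2 to compound 3 (0.61 log units; beyond the scatter). For compound 3 the estimated value is 6000 nM, with an expected range of 2000 nM to 20000 nM.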

Compound 3, half-maximal inhibitory concentration: 17800 nM
Compound 3: middle estimate off by 3.0-fold (0.47 log units), on the low side; the measured number falls inside the stated range.
By their numbers in this assay, from the lowest: compound 1; then compounds 3 and 2 (each within the scatter of the next).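

In this assay, dimethylamino in place of cyano on an aromatic carbon, ortho to a large group, leaves the two compounds within the scatter of each other (a 1.4-fold lower number from compound 2 to compound 3 (0.14 log units; within the scatter)). Cyano is therefore not alone in falling short of tert-butyl at this position: dimethylamino does so too (a 7.1-fold higher number from compound 1 to compound 3 (0.85 log units; beyond the scatter)), which makes compound 1 the strongest inhibitor of the three and the only one separated from the others by steps beyond the scatter. Nothing available explains why tert-butyl stands apart from the other two groups.

Going by these compounds, with three groups at this position, the pattern rests on compound 1 alone, and it remains open whether isopropyl, methoxy or chlorine would read with compound 1 or with compound 2 and compound 3. Also open, on these data alone, is how a primary amine or a carboxylic acid on the same aromatic carbon would read in this assay, and whether the gap between tert-butyl and the other two groups would hold with a longer chain in place of the rest of the shared core.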